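One Group Changed on Compound 1

The source may report more compounds than this note shows. Statements on the series, on what has been measured and on what is new or still open speak of the compounds shown alone.

Compound 1 `C[C@@H](NCc1ccc(Oc2ccccc2)cc1)C(N)=O` gives 64 mg/kg in mice
Compound 2 `CNC(=O)[C@@H](CO)NCc1ccc(OCc2ccccc2F)cc1` gives 12.4 mg/kg in mice

In a functional assay on the whole organism with Mus musculus as the target (a lower number here means that less compound is needed, a higher number that more compound is needed for the effect), compound 1 stands at 64 mg/kg as the higher of the two numbers, and compound 2 lies lower at 12.4 mg/kg by more than the usual scatter. Compound 3 `C[C@@H](NCc1ccc(OCc2ccccn2)cc1)C(N)=O` has not yet been measured. It keeps the core of compound 1 and changes one group: (pyridin-2-yl)methyl in place of phenyl on an oxygen on an aromatic ring. Among the compounds with values here, no step between measured compounds shows what such a swap does in this assay on its own. Compound 2 at 12.4 mg/kg offers the only hint, and it differs from compound 1 in more than one place. A moderate step toward a lower number is therefore expected, with a 2.3-fold lower number from compound 1 to compound 3 (0.36 log units; beyond the scatter) as the estimated size, though the uncertainty is wide. For compound 3 the expected value is 28 mg/kg, with an estimated range from 10 mg/kg to 75 mg/kg until a measurement settles it.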

Compound 3, dose for half-maximal effect: 172 mg/kg
Compound 3: middle estimate off by 6.1-fold (0.79 log units), on the low side; the measured number lies above the stated range.
By their numbers in this assay, from the lowest: compound 2; then compound 1; then compound 3.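

In this assay, within the data shown here, putting (pyridin-2-yl)methyl in place of phenyl on an oxygen on an aromatic ring gives a 2.7-fold higher number from compound 1 to compound 3 (0.43 log units; beyond the scatter), the first step in this set that isolates a single change. It shows that this position is not indifferent to what it carries, and that this swap, which adds a ring nitrogen, a hydrogen-bond acceptor and one heavy atom overall, moves the number upward on the core of compound 1. Nothing available explains the rise.

The compounds shown leave open whether the ring nitrogen or the added carbon link accounts for the step, and a plain benzyl group on the same oxygen would separate the two. From the compounds shown here alone, how a (pyridin-3-yl)methyl group or a longer 2-phenylethyl chain would read there also stays open.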